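Series notes: 2,2-dimethyl-1,3-dioxolan-4-yl to 1,2-dihydroxyethyl

The compounds below may be only part of what the source reports. "The series", "measured", "known", "first", "only" and "open" are said of these compounds alone.

Measured so far:
compound 1 `CC1(C)O[C@@H](CO)[C@H](Cn2cc(Cn3c4c(c5ccccc53)C(=O)c3c[n+]([O-])c5ccccc5c3C4=O)nn2)O1` gives 190 nM in a functional assay on A-375 cells (Homo sapiens) for cytotoxicity, read by MTT assay, with a stated time of 72 h; on this read-out higher numbers stand for weaker inhibition and lower numbers for stronger inhibition
compound 2 `CC1(C)OCC(Cn2cc(Cn3c4c(c5ccccc53)C(=O)c3c[n+]([O-])c5ccccc5c3C4=O)nn2)O1` gives 330 nM in this assay
compound 3 `O=C1c2c[n+]([O-])c3ccccc3c2C(=O)c2c1c1ccccc1n2CCCCN1CCNCC1` gives 460 nM in this assay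

Compound 2 stands second highest of the three numbers; compound 3 is nearest and compound 1 furthest, both within the scatter of it. Compound 4 `O=C1c2c[n+]([O-])c3ccccc3c2C(=O)c2c1c1ccccc1n2Cc1cn(C[C@H](O)CO)nn1` is not yet measured. It differs from compound 2 by 1,2-dihydroxyethyl in place of 2,2-dimethyl-1,3-dioxolan-4-yl on a saturated chain carbon bound to an aromatic nitrogen. Among the compounds with values here, the only measured step at this place is a 1.7-fold higher number from compound 1 to compound 2 (0.24 log units; within the scatter), which stayed within the scatter. Within the data shown here, compound 2 and compound 3 share no single-change step and show only two numbers within the scatter of each other. Among the measured compounds shown here, no measured step here covers loss of the ring, so in this assay no step beyond the scatter is expected in either direction. Compound 4 is therefore estimated at 350 nM, range 120 nM to 1000 nM, an expected step of a 1.1-fold higher number from compound 2 to compound 4 (0.03 log units; within the scatter).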

Compound 4, half-maximal inhibitory concentration: 350 nM
For compound 4 middle estimate and measured number coincide at the digits printed; the range from low to high includes it.
By their numbers in this assay, from the lowest: compounds 1, 2, 4 and 3 (each within the scatter of the next, the first and the last beyond it).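

In this assay, 1,2-dihydroxyethyl in place of 2,2-dimethyl-1,3-dioxolan-4-yl gives a 1.1-fold higher number from compound 2 to compound 4 (0.03 log units; within the scatter) and shows that, on this saturated chain carbon bound to an aromatic nitrogen, loss of the ring moves the number no further than the scatter. Compound 4 also stays within the scatter of the other two compounds, with a 1.8-fold higher number from compound 1 to compound 4 (0.27 log units; within the scatter) and a 1.3-fold lower number from compound 3 to compound 4 (0.12 log units; within the scatter) as the steps. No measurement at hand offers a reason for this result.

Still open, from the compounds shown here alone, is whether an amine or a carboxylic acid in place of 1,2-dihydroxyethyl, or a longer chain bearing the diol, would give a step beyond the scatter.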